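Furan-2-yl in place of thiophen-2-yl: expected step

The source may hold more compounds than are shown below. What is called first, only, known or untested is meant among the compounds shown, and "the series" means these compounds.

In a functional assay on COLO 205 cells (Homo sapiens) for cytotoxicity, read by sulforhodamine B assay, with a stated time of 48 h (on this read-out lower numbers stand for stronger inhibition and higher numbers for weaker inhibition), compound 1 (`COc1cc(/C=C/C(=O)/C=C/c2cccs2)ccc1OCc1cn(CCOc2cc(=O)oc3ccccc23)nn1`) gives 11400 nM as its value. Compound 2 (`COc1ccc(/C=C/C(=O)/C=C/c2ccc(OCc3cn(CCOc4cc(=O)oc5ccccc45)nn3)c(OC)c2)cc1OC`) gives 6780 nM on the same read-out and compound 3 (`COc1ccc(/C=C/C(=O)/C=C/c2ccc(OCc3cn(CCCOc4cc(=O)oc5ccccc45)nn3)c(OC)c2)cc1OC`) gives 13000 nM there. The value of compound 1 lies within the scatter of both others, so it holds no distinct place among the three.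

Compound 4 (`COc1cc(/C=C/C(=O)/C=C/c2ccco2)ccc1OCc1cn(CCOc2cc(=O)oc3ccccc23)nn1`) is not yet measured. It differs from compound 1 in one place: furan-2-yl in place of thiophen-2-yl on a double-bonded chain carbon bound to a double-bonded chain carbon. In words, furan-2-yl stands in place of thiophen-2-yl on a double-bonded chain carbon bound to a double-bonded chain carbon.

Going by the values given here, one measured step touches this same place, with 3,4-dimethoxyphenyl in place of thiophen-2-yl: a 1.7-fold lower number from compound 1 to compound 2 (0.23 log units; within the scatter). Among the compounds with values here, no measurement yet covers furan-2-yl itself. Within the data shown here, with a 1.7-fold lower number from compound 1 to compound 2 (0.23 log units; within the scatter) as the only guide, no step beyond the scatter is expected in this assay. The step expected here is a 1.0-fold lower number from compound 1 to compound 4 (0.02 log units; within the scatter) and no direction is favoured. For compound 4 the estimated value is 11000 nM with an expected range from 5500 nM to 22000 nM as the working figure.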

Compound 4, half-maximal inhibitory concentration: 11800 nM
Compound 4: the middle estimate sits 1.1-fold (0.03 log units) below what was measured; low and high end bracket the measured number.
By their numbers in this assay, from the lowest: compounds 2, 1, 4 and 3 (each within the scatter of the next).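

In this assay, furan-2-yl in place of thiophen-2-yl gives a 1.0-fold higher number from compound 1 to compound 4 (0.01 log units; within the scatter), so exchanging the ring sulfur for oxygen, with the heavy-atom count unchanged, leaves no readable effect at this place. The exchange of furan-2-yl for 3,4-dimethoxyphenyl reads a 1.7-fold higher number from compound 2 to compound 4 (0.24 log units; within the scatter), so thiophen-2-yl, furan-2-yl and 3,4-dimethoxyphenyl all lie within the scatter of one another, and this place has not yet shown any response to the group it carries. No measured evidence is available that bears on this result.

As far as these compounds go, it remains open whether a phenyl ring carrying an amine or a carboxylic acid on the same double-bonded chain carbon would move the number beyond the scatter. Also open, from the compounds shown here alone, is how furan-2-yl behaves on the core of compound 3, with its longer chain.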